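The source may hold more compounds than are shown below. What is called first, only, known or untested is meant among the compounds shown, and "the series" means these compounds.

Measured in an ADME assay on the whole organism (strain FVB) for pharmacokinetics, with Mus musculus as the target, read by LC-MS, at a dose of 30 mg/kg by the oral route; a lower number here means less compound in the circulation, a higher number more compound in the circulation at the dose given:
Compound 1 `NCCOc1ccc([C@H]2CC[C@]3(CC2)OOC2(O3)C3CC4CC(C3)CC2C4)cc1`: 1370 ng.h/mL
Compound 2 `c1cc([C@H]2CC[C@]3(CC2)OOC2(O3)C3CC4CC(C3)CC2C4)ccc1OCCOC1CCNCC1`: 9180 ng.h/mL
Compound 3 `CC(C)(N)CCOc1ccc([C@H]2CC[C@]3(CC2)OOC2(O3)C3CC4CC(C3)CC2C4)cc1`: 12300 ng.h/mL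

Compound 3 stands well clear of compound 1, with a 9.0-fold higher number from compound 1 to compound 3 (0.95 log units; beyond the scatter). It cannot be told apart from compound 2, with a 1.3-fold higher number from compound 2 to compound 3 (0.13 log units; within the scatter). Compound 4 `c1cc([C@H]2CC[C@]3(CC2)OOC2(O3)C3CC4CC(C3)CC2C4)ccc1OCCC1CCNCC1` keeps the shared core and the chain oxygen but changes the end group: piperidin-4-yl in place of 1-amino-1-methylethyl on a saturated chain carbon, two bonds along the chain from an oxygen on an aromatic ring. In words, this is piperidin-4-yl in place of 1-amino-1-methylethyl on a saturated chain carbon, two bonds along the chain from an oxygen on an aromatic ring.

Within the data shown here, no measured step makes this exact exchange. The closest guide is compound 2, which carries (piperidin-4-yl)oxy and shows a 6.7-fold higher number from compound 1 to compound 2 (0.83 log units; beyond the scatter), a rise of similar size to that of compound 3. A piperidine end group therefore gives no reason to expect a step beyond the scatter in this assay, though a slight fall is possible. The expected step is a 1.5-fold lower number from compound 3 to compound 4 (0.19 log units; within the scatter). For compound 4 the estimated value is 8000 ng.h/mL, with an expected range of 3000 ng.h/mL to 20000 ng.h/mL.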

Compound 4, area under the concentration-time curve: 16000 ng.h/mL
Estimate against measurement, compound 4: 2.0-fold (0.30 log units) below, within the range that was stated.
By their numbers in this assay, from the lowest: compound 1; then compounds 2, 3 and 4 (each within the scatter of the next).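

In this assay, the piperidin-4-yl end group, on a saturated chain carbon two bonds along the chain from an oxygen on an aromatic ring, stands well clear of the amino group, with a 12-fold higher number from compound 1 to compound 4 (1.07 log units; beyond the scatter). Against the other two end groups it cannot be told apart, with a 1.3-fold higher number from compound 3 to compound 4 (0.11 log units; within the scatter) and a 1.7-fold higher number from compound 2 to compound 4 (0.24 log units; within the scatter), so piperidin-4-yl, (piperidin-4-yl)oxy and 1-amino-1-methylethyl all stand clear of amino at this position and none separates from the others. Nothing shown here accounts for this difference from amino.

The compounds shown leave open whether an end group without nitrogen, such as a hydroxyl or a carboxylic acid, would also stand clear of amino. They also leave open whether a piperidine with a methyl on its nitrogen, or piperidin-4-yl on a longer chain, would stay level with compound 4.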